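Trimethoxybenzoyl pyrroles: swapping the fluorophenyl for aminophenyl

The source may hold more compounds than are shown below. What is called first, only, known or untested is meant among the compounds shown, and "the series" means these compounds.

Measured so far:
compound 1, `COc1cc(C(=O)c2cn(-c3ccccc3)cc2-c2ccccc2F)cc(OC)c1OC` — 30 nM in a functional assay on MCF7 cells (Homo sapiens) for inhibition, read by trypan blue exclusion, with a stated time of 3 days; on this read-out lower numbers stand for stronger inhibition and higher numbers for weaker inhibition
compound 2, `COc1cc(C(=O)c2cn(-c3ccccc3)cc2-c2ccc(C)cc2)cc(OC)c1OC` — 280 nM

Compound 1 stands at the lowest number of the two measured compounds; its nearest neighbour is compound 2, and the step of a 9.3-fold higher number from compound 1 to compound 2 (0.97 log units; beyond the scatter) lies beyond the scatter, so compound 1 is the stronger inhibitor of the pair. That step is the only one on record, and it comes from putting 4-methylphenyl in place of 2-fluorophenyl on an aromatic carbon of the shared core.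

The compound now to be judged is compound 3, `COc1cc(C(=O)c2cn(-c3ccccc3)cc2-c2ccc(N)cc2)cc(OC)c1OC`. It differs from compound 1 in one place: 4-aminophenyl in place of 2-fluorophenyl on an aromatic carbon. As in the step to compound 2, the 2-fluorophenyl leaves and a phenyl carrying a group in the 4-position enters, though here that group is an amine rather than a methyl. Among the measured compounds shown here, the step of a 9.3-fold higher number from compound 1 to compound 2 (0.97 log units; beyond the scatter) is the only guide, and it was modest but clearly beyond the scatter, pointing toward a higher number. A step of similar size and direction, a 6.7-fold higher number from compound 1 to compound 3 (0.82 log units; beyond the scatter), is therefore expected. Compound 3 is expected to give about 200 nM, within a range of 60 nM to 700 nM.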

Compound 3, half-maximal inhibitory concentration: 9 nM
Estimate against measurement, compound 3: 22-fold (1.35 log units) above; measured number outside the range, below it.
By their numbers in this assay, from the lowest: compound 3; then compound 1; then compound 2.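

Compound 2 alone could have suggested that replacing 2-fluorophenyl at this place on the shared core simply costs activity, but in this assay the change to 4-aminophenyl moves the other way, with a 3.3-fold lower number from compound 1 to compound 3 (0.52 log units; beyond the scatter). Among these three compounds, then, the outcome of leaving 2-fluorophenyl depends on which group enters, and 4-methylphenyl and 4-aminophenyl fall on opposite sides of it. The exchange of methyl for amino on that phenyl gives the largest step here, a 31-fold lower number from compound 2 to compound 3 (1.49 log units; beyond the scatter), yet nothing available shows why the amino group has this effect.

The compounds shown leave open whether this gain is particular to the amino group or would also appear with 4-hydroxyphenyl or 4-methoxyphenyl at the same place. They also leave open whether the amino hydrogens matter, which a comparison with 4-(dimethylamino)phenyl could test, and whether the ranking of these groups would hold in cells other than those of this single read-out.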